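A few compounds are considered here, and "the series" means these few. Any claim that something is new, unique, unknown or untested is made for them only; others in the source may bear on it.

Compound 1 `COc1ccc(OCC2=NCCO2)cc1`: 50%
Compound 2 `Brc1ccc(OCC2=NCCO2)cc1`: 60%

Within the data shown here, in a toxicity assay on the whole organism with Rattus norvegicus as the target, at a dose of 100 mg/kg by the oral route (a lower number here means a weaker effect, a higher number a stronger effect of the compound at the dose given), compound 2 gives the nominally higher of the two numbers, but the single measured step of a number 10 percentage points higher from compound 1 to compound 2 (within the scatter) lies within the scatter, so the two compounds cannot be told apart. Compound 3 `O=[N+]([O-])c1ccc(OCC2=NCCO2)cc1` differs from compound 2 by nitro in place of bromo on an aromatic carbon. Among the measured compounds shown here, the one step measured so far concerns a different exchange and was itself within the scatter, so it gives no firm guide. The step of a number 5 percentage points lower from compound 2 to compound 3 (within the scatter) is therefore expected to stay within the scatter. Compound 3 is estimated at 55%, within a range of 35% to 75%.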

Compound 3, a percentage reported as activity, at one dose (the size of the read-out at that dose, not a potency): 50%
Beside the measured number, compound 3's estimate is 5 percentage points above it; the range from low to high includes it.
By their numbers in this assay, from the lowest: compounds 1, 3 and 2 (each within the scatter of the next).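

In this assay, nitro in place of bromo gives a number 10 percentage points lower from compound 2 to compound 3 (within the scatter), and nitro in place of methoxy gives no change at the digits printed from compound 1 to compound 3 (within the scatter). A third group on this aromatic carbon, with more heavy atoms than bromo, therefore leaves all three compounds indistinguishable at this dose. Nothing at hand gives a reason for this result. As far as these compounds go, it remains open whether another group on this carbon, such as an amine or a carboxylic acid, would move the number beyond the scatter. From the compounds shown here alone, the effect of a change elsewhere in the shared core also remains open.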